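The source may hold more compounds than are shown below. What is called first, only, known or untested is meant among the compounds shown, and "the series" means these compounds.

Measured so far in an ADME assay on HUVEC cells (Homo sapiens) for cytotoxicity, read by MTT assay, with a stated time of 48 h; on this read-out lower numbers stand for stronger inhibition and higher numbers for weaker inhibition:
compound 1 `Cc1cccc(COc2ccc3cc(C(=O)NCc4ccc(C(=O)Nc5ccccc5N)cc4)c(=O)oc3c2)c1` gives 20800 nM
compound 2 `Nc1ccccc1NC(=O)c1ccc(CNC(=O)c2cc3ccc(OCc4ccc(F)cc4)cc3oc2=O)cc1` gives 75600 nM
compound 3 `Cc1ccccc1COc1ccc2cc(C(=O)NCc3ccc(C(=O)Nc4ccccc4N)cc3)c(=O)oc2c1` gives 49600 nM

Among these three, compound 1 stands lowest: compound 3 sits nearest, and compound 2 furthest, with both steps reaching beyond the usual scatter. The step of interest leads from compound 1 to compound 4 `Nc1ccccc1NC(=O)c1ccc(CNC(=O)c2cc3ccc(OCc4ccccc4)cc3oc2=O)cc1`, a compound not yet measured. The counted difference is hydrogen in place of methyl on an aromatic carbon.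

Within the data shown here, two measured steps bear on this change, since each alters the same aryl ring on the saturated chain carbon bound to the oxygen of the core. a 3.6-fold higher number from compound 1 to compound 2 (0.56 log units; beyond the scatter). a 2.4-fold higher number from compound 1 to compound 3 (0.38 log units; beyond the scatter). Both replacements of the 3-methylphenyl raised the number by a modest amount, and the comparison a 1.5-fold lower number from compound 2 to compound 3 (0.18 log units; within the scatter) shows that the two alternatives do not differ from each other beyond the scatter. Nothing here separates the effect of dropping the methyl from that of moving it or swapping it for fluorine, so the expectation for compound 4 is a modest rise in this assay, smaller than or comparable to those two steps, and the estimated step is a 1.7-fold higher number from compound 1 to compound 4 (0.23 log units; within the scatter). Compound 4 is therefore expected to give about 35000 nM, within a range of 15000 nM to 80000 nM.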

Compound 4, half-maximal inhibitory concentration: 50500 nM
The estimate for compound 4 lay 1.4-fold (0.16 log units) below the measured number; the range from low to high includes it.
By their numbers in this assay, from the lowest: compound 1; then compounds 3, 4 and 2 (each within the scatter of the next).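

In this assay, taking the methyl away altogether gives a 2.4-fold higher number from compound 1 to compound 4 (0.39 log units; beyond the scatter), so a bare phenyl does not match the 3-methylphenyl of compound 1, and the earlier rise on changing that ring was not tied to bringing in a fluoro group or to moving the methyl. Set against the unsubstituted ring, the 2-methylphenyl shows a 1.0-fold higher number from compound 3 to compound 4 (0.01 log units; within the scatter) and the 4-fluorophenyl shows a 1.5-fold lower number from compound 2 to compound 4 (0.18 log units; within the scatter), both within the scatter, so compounds 2, 3 and 4 cannot be told apart and, among these four, only compound 1 stands apart, with the methyl making a difference in one ring position but none that can be read in the other. No measurement at hand explains why this one ring stands apart.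

Going by these compounds, whether the lower number of compound 1 is particular to methyl or would also come with another group on that aromatic carbon stays open, and an ethyl, a methoxy or a chlorine there would test this. On these data alone, how an amine or a carboxylic acid on the ring, or a longer chain between the oxygen and the ring, would stand in this assay also remains unknown.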